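Methanesulfonamide in place of the aniline hydrogen

The source may report more compounds than this note shows. Statements on the series, on what has been measured and on what is new or still open speak of the compounds shown alone.

Measured so far:
compound 1 `CNc1ccccc1N1CCN(CCCCCC(=O)NC2CCCc3ccccc32)CC1` — 25.4 nM
compound 2 `Nc1ccccc1N1CCN(CCCCCC(=O)NC2CCCc3ccccc32)CC1` — 8180 nM

Of the compounds shown here, two have been tested in an assay on HEK293 cells for displacement of a labelled ligand from 5-hydroxytryptamine receptor 7 (Rattus norvegicus); a lower number here means a stronger inhibitor, a higher number a weaker inhibitor. Compound 1 `CNc1ccccc1N1CCN(CCCCCC(=O)NC2CCCc3ccccc32)CC1` gives 25.4 nM, and compound 2 `Nc1ccccc1N1CCN(CCCCCC(=O)NC2CCCc3ccccc32)CC1` gives 8180 nM. Among the measured compounds shown here, the only step between them, a 320-fold higher number from compound 1 to compound 2 (2.51 log units; beyond the scatter), is a hydrogen in place of methyl on a nitrogen on an aromatic ring. Compound 2 therefore stands at the highest of the two numbers, with compound 1 the nearest and far lower.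

Compound 3 `CS(=O)(=O)Nc1ccccc1N1CCN(CCCCCC(=O)NC2CCCc3ccccc32)CC1` has not yet been measured. It differs from compound 2 by methylsulfonyl in place of hydrogen on a nitrogen on an aromatic ring: amino becomes methanesulfonamido, 2-aminophenyl becomes 2-(methanesulfonamido)phenyl. For the measured compounds named here, the one measured step that bears on this change is a 320-fold higher number from compound 1 to compound 2 (2.51 log units; beyond the scatter), which shows that the bare amino of compound 2 goes with a far higher number than its methylated counterpart. Whether a methylsulfonyl on that nitrogen acts like a methyl is not known from these data. A lower number than that of compound 2 is expected, but with wide uncertainty, so the step is estimated as a 5.5-fold lower number from compound 2 to compound 3 (0.74 log units; beyond the scatter). For compound 3 the expected value in this assay is 1500 nM, within a range of 150 nM to 10000 nM.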

Compound 3, inhibition constant: 4250 nM
Compound 3: the middle estimate sits 2.8-fold (0.45 log units) below what was measured; measured number inside the range.
By their numbers in this assay, from the lowest: compound 1; then compounds 3 and 2 (each within the scatter of the next).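

In this assay, the methylsulfonyl group on this nitrogen leaves the reading where the bare amino group had it (a 1.9-fold lower number from compound 2 to compound 3 (0.28 log units; within the scatter)), so compound 2 and compound 3 cannot be told apart here, even though 4 heavy atoms have been added at this position. The earlier pair could suggest that any group on this nitrogen might restore a low number, but the new comparison with the methyl compound (a 170-fold higher number from compound 1 to compound 3 (2.22 log units; beyond the scatter)) shows that this does not hold for methylsulfonyl: of the three groups tested here, only methyl goes with a low number. No measurement shown here explains why methyl and methylsulfonyl part so widely at this position.

Three groups on one nitrogen cannot show whether the low number belongs to methyl alone, or whether an ethyl group or a longer chain on that nitrogen, or a second methyl giving dimethylamino, would keep it. An acetyl group would also be informative, since it would show whether a carbonyl attached at this nitrogen tracks with methylsulfonyl or with methyl.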